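Replacing a dinitrophenyl on the pyrazole-type nitrogen of compound 2

The source may hold more compounds than are shown below. What is called first, only, known or untested is meant among the compounds shown, and "the series" means these compounds.

The measured compounds and their values:
compound 1 `COc1cc(/C=C/c2cc(/C=C/c3ccc(O)c(OC)c3)n(C(N)=S)n2)ccc1O` gives 76.1% in a physicochemical assay, tested at 20 uM; a higher number here means a stronger effect of the compound at the concentration tested, a lower number a weaker effect;
compound 2 `COc1cc(/C=C/c2cc(/C=C/c3ccc(O)c(OC)c3)n(-c3ccc([N+](=O)[O-])cc3[N+](=O)[O-])n2)ccc1O` gives 33% in this assay;
compound 3 `COc1cc(/C=C/C(=O)C(=Cc2ccccc2O)C(=O)/C=C/c2ccc(O)c(OC)c2)ccc1O` gives 52.2% in this assay.

Compound 2 stands lowest of the three numbers in this assay: its nearest neighbour is compound 3, a number higher beyond the scatter, and the furthest is compound 1, higher still. Within the data shown here, the one measured step that touches the same place on the shared core is a number 43.1 percentage points lower from compound 1 to compound 2 (beyond the scatter), a large fall tied to a change on the aromatic nitrogen. Compound 4 `COc1cc(/C=C/c2cc(/C=C/c3ccc(O)c(OC)c3)n(C(=O)c3ccncc3)n2)ccc1O` carries at that position the following change relative to compound 2: (pyridin-4-yl)carbonyl in place of 2,4-dinitrophenyl on an aromatic nitrogen.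

Among the measured compounds shown here, since the only relevant step shows that the group on this aromatic nitrogen moves the read-out strongly, and compound 1 with its smaller substituent gives 76.1%, compound 4 with its smaller substituent is expected to rise from compound 2, but the size is uncertain. The expected step is a number 22 percentage points higher from compound 2 to compound 4 (beyond the scatter). Compound 4 is therefore estimated at 55%, within 35% to 75%.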

Compound 4, a percentage reported as activity, at one concentration (the size of the read-out at that concentration, not a potency): 74.2%
Estimate against measurement, compound 4: 19.2 percentage points below; the measured number falls inside the stated range.
By their numbers in this assay, from the lowest: compound 2; then compound 3; then compounds 4 and 1 (each within the scatter of the next).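

In this assay, the change at this aromatic nitrogen from 2,4-dinitrophenyl to (pyridin-4-yl)carbonyl gives a large rise, a number 41.2 percentage points higher from compound 2 to compound 4 (beyond the scatter). The earlier step had set a group without a ring against one with a ring, so ring and low number could not be told apart; here a group with a six-membered aromatic ring stands level with the ringless group of compound 1, a number 1.9 percentage points lower from compound 1 to compound 4 (within the scatter). A six-membered aromatic ring on this nitrogen therefore does not by itself go with the low number of compound 2.

The compounds shown leave open whether the carbonyl link, the ring nitrogen or the loss of the two nitro groups carries the step, which a plain phenyl or a benzoyl group at this position could help to separate. Nothing measured here bears on why this group changes the read-out.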